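A few compounds are considered here, and "the series" means these few. Any claim that something is new, unique, unknown or untested is made for them only; others in the source may bear on it.

Measured so far:

Compound 1 `CCCCn1ccc2cc(/C(C)=C/C(=O)Nc3ccccc3OCCCC(=O)O)ccc21` gives 43 nM in an assay on Prostate gland for inhibition of steroid 5-alpha-reductase (Rattus norvegicus); on this read-out lower numbers stand for stronger inhibition and higher numbers for weaker inhibition.
Compound 2 `CCCCCn1ccc2cc(/C(C)=C/C(=O)Nc3ccccc3OCCCC(=O)O)ccc21` gives 23 nM in this assay.
Compound 3 `CCCC(CC)n1ccc2cc(/C(C)=C/C(=O)Nc3ccccc3OCCCC(=O)O)ccc21` gives 9.3 nM in this assay.

All three share one core and differ only in the chain carried on the aromatic nitrogen. The change from compound 1 to compound 2 is methyl in place of hydrogen on a saturated chain carbon, four bonds along the chain from an aromatic nitrogen, and it made a 1.9-fold lower number from compound 1 to compound 2 (0.27 log units; within the scatter). The change from compound 1 to compound 3 is ethyl in place of hydrogen on a saturated chain carbon bound to an aromatic nitrogen and a saturated chain carbon, and it made a 4.6-fold lower number from compound 1 to compound 3 (0.66 log units; beyond the scatter); from compound 2 to compound 3 the step was a 2.5-fold lower number from compound 2 to compound 3 (0.39 log units; beyond the scatter). Compound 3 stands with the lowest number of the three.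

The compound not yet measured is compound 4 `CCCC(C(C)C)n1ccc2cc(/C(C)=C/C(=O)Nc3ccccc3OCCCC(=O)O)ccc21`. Compared with compound 3, the change is methyl in place of hydrogen on a saturated chain carbon bound to two saturated chain carbons. Going by the values given here, this is the same kind of change as the one from compound 1 to compound 2, an added methyl on a saturated chain carbon, but the surroundings differ: in the earlier case the carbon sits four bonds along the chain from an aromatic nitrogen, here it is bound to two saturated chain carbons. The two cores, compound 1 against compound 3, differ by ethyl in place of hydrogen on a saturated chain carbon bound to an aromatic nitrogen and a saturated chain carbon.

Because the earlier methyl step gave a 1.9-fold lower number from compound 1 to compound 2 (0.27 log units; within the scatter), a small step in the same direction is expected for compound 4, estimated at a 1.3-fold lower number from compound 3 to compound 4 (0.12 log units; within the scatter). Compound 4 is expected to give about 7 nM in this assay, between 3 nM and 18 nM.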

Compound 4, half-maximal inhibitory concentration: 7.2 nM
For compound 4 the middle estimate is 1.0-fold (0.01 log units) below the measured one; the measured number falls inside the stated range.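

Set side by side in this assay, the added methyl gives steps on the two cores that cannot be told apart: the same change on two cores in this assay, a 1.9-fold lower number (0.27 log units; within the scatter) from compound 1 to compound 2 and a 1.3-fold lower number (0.11 log units; within the scatter) from compound 3 to compound 4, 1.4-fold (0.16 log units) apart, within the scatter of two such steps. This shows that the change carried from the core of compound 1 to the core of compound 3 with no visible difference in its effect, but each step lies within the scatter on its own, so it does not show that the methyl itself strengthens inhibition on either core, nor how it would behave on a third core. The single methyl gives only a 1.3-fold lower number from compound 3 to compound 4 (0.11 log units; within the scatter), whereas the clear moves come from changing the whole chain on the aromatic nitrogen, with a 3.2-fold lower number from compound 2 to compound 4 (0.50 log units; beyond the scatter) and a 6.0-fold lower number from compound 1 to compound 4 (0.78 log units; beyond the scatter), and these two steps cannot separate the effect of the methyl from that of the rest of the chain.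

The compounds shown leave open what an amine, a hydroxyl or a longer branched chain would do in place of the 1-isopropylbutyl chain on the aromatic nitrogen. They also leave open whether the carboxylic acid could be replaced by an amide or an alcohol while the numbers stay this low.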